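The compounds below may be only part of what the source reports. "The series", "measured", "known", "first", "only" and "open" are said of these compounds alone.

Compound 1 `O=C(N/N=C\c1ccccn1)c1ccc(-c2nc3ccccc3s2)cc1`, compound 2 `O=C(N/N=C/c1ccc(O)c(O)c1)c1ccc(-c2nc3ccccc3s2)cc1` and compound 3 `O=C(N/N=C/c1ccc(O)cc1O)c1ccc(-c2nc3ccccc3s2)cc1` share one core and differ only in the group hanging from the amide-type nitrogen. In an assay on isolated protein for inhibition of Maltase-glucoamylase (Homo sapiens), with a stated time of 15 min (a higher number here means a weaker inhibitor, a lower number a stronger inhibitor), compound 1 gives 10200 nM, compound 2 gives 15100 nM and compound 3 gives 5580 nM; compound 1 lies within the scatter of both. Going by the values given here, the one step in this set, a 2.7-fold lower number from compound 2 to compound 3 (0.43 log units; beyond the scatter), swaps hydroxyl positions on that ring. Among the compounds with values here, compound 4 `O=C(N/N=C/c1ccc(Cl)cc1)c1ccc(-c2nc3ccccc3s2)cc1` instead carries a group of 9 heavy atoms (7 carbon, 1 nitrogen, 1 chlorine; one six-membered aromatic ring of carbon only) in place of a group of 8 heavy atoms (6 carbon, 2 nitrogen; one six-membered aromatic ring with 1 hetero atom), on an amide-type nitrogen, a change no measured step covers, so the expectation for a 1.3-fold lower number from compound 1 to compound 4 (0.11 log units; within the scatter) is a step of modest size at most, direction uncertain. Compound 4 is therefore estimated at 8000 nM, with a range from 2500 nM to 25000 nM.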

Compound 4, half-maximal inhibitory concentration: 5310 nM
For compound 4 the middle estimate is 1.5-fold (0.18 log units) above the measured one; the measured number falls inside the stated range.
By their numbers in this assay, from the lowest: compounds 4, 3, 1 and 2 (each within the scatter of the next, the first and the last beyond it).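

A ring with no hydroxyl can match a ring with two, since the change to 4-chlorophenyl gives (a 1.1-fold lower number from compound 3 to compound 4 (0.02 log units; within the scatter)) in this assay. The same group separates clearly from the 3,4-dihydroxyphenyl group, with (a 2.8-fold lower number from compound 2 to compound 4 (0.45 log units; beyond the scatter)), but not from the group in the other comparison, with (a 1.9-fold lower number from compound 1 to compound 4 (0.28 log units; within the scatter)). Nothing available explains these differences. Whether chlorine itself matters stays open, as no compound shown has an unsubstituted phenyl, a bromine or a methyl in its place. How an amine or a carboxylic acid on this ring would behave is also unknown.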